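A few compounds are considered here, and "the series" means these few. Any claim that something is new, unique, unknown or untested is made for them only; others in the source may bear on it.

Compound 1 `Cc1cc(O)c(C2=NN(c3ccc(S(N)(=O)=O)cc3)C(c3ccccc3O)C2)cc1Cl` gives 33400 nM in a functional assay on ACHN cells (Homo sapiens) for antiproliferative activity, with a stated time of 48 h; a lower number here means that less compound is tolerated, a higher number that more compound is tolerated. Compound 2 `COc1ccc(C2CC(c3cc(Cl)c(C)cc3O)=NN2c2ccc(S(N)(=O)=O)cc2)cc1OC` carries a 3,4-dimethoxyphenyl group where compound 1 has a 2-hydroxyphenyl group. In this assay compound 2 reaches only a limit of the measurement, > 100000 nM. That step, an at least 2.9-fold higher number from compound 1 to compound 2 (0.47 log units; beyond the scatter), places compound 2 at the limit of > 100000 nM in this assay, at which 1 of the 2 values shown sits, so its true value is known only as lying beyond that point. Compound 3 `COc1ccc(C2CC(c3cc(Cl)c(C)cc3O)=NN2c2ccc(S(N)(=O)=O)cc2)c(OC)c1OC` differs from compound 2 in one place: methoxy in place of hydrogen on an aromatic carbon. Going by the values given here, no measured step follows a methoxy added to this aromatic ring, so the only bearing on the change comes from the position of compound 2 itself, already at the limit. Compound 3 is therefore expected to stay at or beyond that limit, a step that the limit leaves unreadable from compound 2 to compound 3 not beyond the scatter. The estimate for compound 3 is 150000 nM, within 50000 nM to 500000 nM, most likely again reported only as a limit.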

Compound 3, concentration lethal to 50% of the cells: 39300 nM
Compound 3: the middle estimate sits 3.8-fold (0.58 log units) above what was measured; the measured number lies below the stated range.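

In this assay, the change from 3,4-dimethoxyphenyl to 2,3,4-trimethoxyphenyl gives an at least 2.5-fold lower number from compound 2 to compound 3 (0.40 log units; beyond the scatter), so a methoxy group on this aromatic carbon, ortho to a methoxy group and to a large group, does register in this read-out. Going by these compounds, the full size of that step stays unknown because compound 2 stands only at a limit of the assay: the limit of > 100000 nM in this assay, at which 1 of the 3 values shown sits. Exchanging 2-hydroxyphenyl for 2,3,4-trimethoxyphenyl gives a 1.2-fold higher number from compound 1 to compound 3 (0.07 log units; within the scatter), so these two groups cannot be told apart here, and a value inside the measured range on this saturated ring carbon does not depend on the 2-hydroxyphenyl group.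

The compounds shown leave open whether only methoxy does this at that aromatic carbon, or whether a fluorine, an amine or a longer chain such as ethoxy would do the same. They also leave open whether the methoxy group would act alike on a phenyl ring without the other two methoxy groups.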